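From an amide to a urea on the shared core

The source may report more compounds than this note shows. Statements on the series, on what has been measured and on what is new or still open speak of the compounds shown alone.

compound 1 `Nc1ccc2cccc(OCCNCc3ccoc3)c2n1` — > 10000 nM
compound 2 `COc1cccc(C(=O)NCCCOc2cccc3ccc(N)nc23)c1` — 30 nM

The study measures inhibition in a functional assay on IMR-32 cells with melanin-concentrating hormone receptor 1 (Homo sapiens) as the target, read by fluorescence; on this read-out higher numbers stand for weaker inhibition and lower numbers for stronger inhibition. Compound 1 `Nc1ccc2cccc(OCCNCc3ccoc3)c2n1` gives > 10000 nM there, which is a limit of the assay and not a number. Compound 2 `COc1cccc(C(=O)NCCCOc2cccc3ccc(N)nc23)c1` gives 30 nM in this assay. That leaves compound 2 holding the only number shown. The remaining value sits at the limit of > 10000 nM in this assay, at which 1 of the 2 values shown sits.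

Compound 3 `Nc1ccc2cccc(OCCCNC(=O)Nc3cccc(Cl)c3)c2n1` differs from compound 2 in one place: (3-chlorophenyl)amino in place of 3-methoxyphenyl on a carbonyl carbon. Within the data shown here, no measured pair shows a step of this kind, so the expectation rests on compound 2 alone. In this assay the expected step is a 1.3-fold higher number from compound 2 to compound 3 (0.12 log units; within the scatter), no bigger than the scatter and in no set direction. Compound 3 is therefore estimated to give about 40 nM in this assay, with a range from 10 nM to 200 nM.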

Compound 3, half-maximal inhibitory concentration: 8 nM
The estimate for compound 3 lay 5.0-fold (0.70 log units) above the measured number, and the stated range ends above it.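

The carbonyl carbon of compound 2 turns out to accept a different group without any loss: in this assay the change to (3-chlorophenyl)amino gives a 3.8-fold lower number from compound 2 to compound 3 (0.57 log units; beyond the scatter), so the urea of compound 3 inhibits more strongly than the amide. Among these compounds, this is the first measured step at this position, and it shows that the group on the carbonyl carbon can shift the read-out. The change exchanges one hydrogen-bond acceptor for one hydrogen-bond donor and also puts chlorine where the methoxy group stood, and nothing measured here gives a reason for the step.

The compounds shown leave open how much of the step belongs to the new nitrogen and how much to the chlorine, which (3-methoxyphenyl)amino or 3-chlorophenyl on the same carbonyl carbon could separate. They also leave open whether a urea carrying a longer chain or an unsubstituted phenylamino group would hold this level.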